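Swapping the aromatic arm of compound 2

The compounds below may be only part of what the source reports. "The series", "measured", "known", "first", "only" and "open" are said of these compounds alone.

Measured so far:
compound 1, `Cn1cccc1-c1ncnc2c1ncn2C1O[C@H](CO)[C@@H](O)[C@H]1O`, giving 15700 nM
compound 2, `OC[C@H]1OC(n2cnc3c(-c4cc[nH]n4)ncnc32)[C@H](O)[C@@H]1O`, giving 1170 nM
compound 3, `OC[C@H]1OC(n2cnc3c(-c4ccc(F)cc4)ncnc32)[C@H](O)[C@@H]1O`, giving 6300 nM

In a functional assay on HL-60 cells (Homo sapiens) for inhibition (a lower number here means a stronger inhibitor, a higher number a weaker inhibitor), compound 2 stands at the lowest number of the three. Its nearest neighbour is compound 3, with a 5.4-fold higher number from compound 2 to compound 3 (0.73 log units; beyond the scatter), and the furthest is compound 1, with a 13-fold lower number from compound 1 to compound 2 (1.13 log units; beyond the scatter).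

Compound 4, `OC[C@H]1OC(n2cnc3c(-c4ccc(O)cc4)ncnc32)[C@H](O)[C@@H]1O`, differs from compound 2 in a single place: 4-hydroxyphenyl in place of 1H-pyrazol-3-yl on an aromatic carbon. Among the compounds with values here, two measured steps bear on this. The closest parallel is a 5.4-fold higher number from compound 2 to compound 3 (0.73 log units; beyond the scatter), where the same 1H-pyrazol-3-yl gave way to a six-membered carbon ring carrying a different substituent, and the number rose modestly. The step of a 2.5-fold lower number from compound 1 to compound 3 (0.40 log units; beyond the scatter) shows a six-membered carbon ring entering at the same place from a different starting group, with a modest fall. Within the data shown here, only one such ring has been tried, so the evidence is thin, but a modest rise in number from compound 2 seems the most likely outcome.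

Compound 4 is therefore expected to give about 3500 nM, within a range of 1200 nM to 10000 nM, which means an estimated 3.0-fold higher number from compound 2 to compound 4 (0.48 log units; beyond the scatter).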

Compound 4, half-maximal inhibitory concentration: 7600 nM
Beside the measured number, compound 4's estimate is 2.2-fold (0.34 log units) below it; low and high end bracket the measured number.
By their numbers in this assay, from the lowest: compound 2; then compounds 3 and 4 (each within the scatter of the next); then compound 1.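

In this assay, a second six-membered carbon ring also does worse than 1H-pyrazol-3-yl at this aromatic carbon (a 6.5-fold higher number from compound 2 to compound 4 (0.81 log units; beyond the scatter)), yet it still improves on 1-methyl-1H-pyrrol-2-yl (a 2.1-fold lower number from compound 1 to compound 4 (0.32 log units; beyond the scatter)). Replacing fluoro with hydroxy on that ring has no readable effect (a 1.2-fold higher number from compound 3 to compound 4 (0.08 log units; within the scatter)), so these two substituents cannot be told apart in this measurement. No supporting measurement is available to explain these differences.

The compounds shown leave open whether an amine or a carboxylic acid on the phenyl ring would bring the number closer to that of compound 2. They also leave open whether the advantage of compound 2 survives a methyl group on the pyrazole nitrogen, or a change to another five-membered ring such as imidazole.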